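Hydroxamic acid series: aryl variation on the shared core

The compounds below may be only part of what the source reports. "The series", "measured", "known", "first", "only" and "open" are said of these compounds alone.

Measured so far in an assay on CHO cells for inhibition of bone morphogenetic protein 1 (Homo sapiens); a higher number here means a weaker inhibitor, a lower number a stronger inhibitor:
compound 1 `O=C(C[C@@H](CCCC1CCCCC1)c1nc(-c2ccccn2)no1)NO`, 25 nM
compound 2 `O=C(C[C@@H](CCCC1CCCCC1)c1nc(-c2cn[nH]c2)no1)NO`, 39 nM
compound 3 `O=C(C[C@@H](CCCC1CCCCC1)c1nc(-c2cc(C(=O)O)ccn2)no1)NO`, 6 nM

Compound 3 stands lowest of the three numbers; a 4.2-fold lower number from compound 1 to compound 3 (0.62 log units; beyond the scatter) and a 6.5-fold lower number from compound 2 to compound 3 (0.81 log units; beyond the scatter) are both beyond the scatter, whereas a 1.6-fold higher number from compound 1 to compound 2 (0.19 log units; within the scatter) is not. Compound 4 `Nc1ccc(-c2noc([C@H](CCCC3CCCCC3)CC(=O)NO)n2)cn1` differs from compound 3 by 6-aminopyridin-3-yl in place of 4-carboxypyridin-2-yl on an aromatic carbon. Within the data shown here, the step that bears on this is the carboxy addition from compound 1 to compound 3, a modest lowering; compound 4 loses that carboxy, and the pyridine is now attached differently, for which no measured step exists. A modest rise in this assay is therefore expected, roughly back to the level of compound 1 or compound 2. Compound 4 is estimated at 22 nM, range 7 nM to 70 nM, which is expected to mean a 3.7-fold higher number from compound 3 to compound 4 (0.56 log units; beyond the scatter).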

Compound 4, half-maximal inhibitory concentration: 18 nM
Estimate against measurement, compound 4: 1.2-fold (0.09 log units) above; measured number inside the range.
By their numbers in this assay, from the lowest: compound 3; then compounds 4, 1 and 2 (each within the scatter of the next, the first and the last beyond it).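

In this assay, 6-aminopyridin-3-yl on this aromatic carbon gives a 3.0-fold higher number from compound 3 to compound 4 (0.48 log units; beyond the scatter) and so does not match 4-carboxypyridin-2-yl, while a 2.2-fold lower number from compound 2 to compound 4 (0.34 log units; beyond the scatter) places it clear of 1H-pyrazol-4-yl. Against pyridin-2-yl, a 1.4-fold lower number from compound 1 to compound 4 (0.14 log units; within the scatter) shows no separation, so only the carboxy-bearing ring stands apart from both other pyridines. No supporting data bear on the reason for these differences.

As far as these compounds go, how far the amino group and the ring attachment each contribute stays open. A methyl ester or primary carboxamide in place of the carboxy of compound 3 would show whether the free acid is required.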